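From bromo to chloro against MCF7 cells

The source may hold more compounds than are shown below. What is called first, only, known or untested is meant among the compounds shown, and "the series" means these compounds.

Compound 1 `NS(=O)(=O)c1ccc(C(=O)N/N=C(/CS(=O)(=O)c2ccccc2)c2ccc(Cl)cc2)cc1`: 57000 nM
Compound 2 `NS(=O)(=O)c1ccc(N/N=C(/CS(=O)(=O)c2ccccc2)c2ccccc2)cc1`: 3970 nM
Compound 3 `NS(=O)(=O)c1ccc(N/N=C(/CS(=O)(=O)c2ccccc2)c2ccc(Br)cc2)cc1`: 17300 nM

In a functional assay on MCF7 cells (Homo sapiens) for antiproliferative activity, read by MTT assay (on this read-out higher numbers stand for weaker inhibition and lower numbers for stronger inhibition), compound 3 holds the middle of the three numbers, with compound 1 higher, compound 2 lower, and both gaps beyond the scatter. Compound 4 `NS(=O)(=O)c1ccc(N/N=C(/CS(=O)(=O)c2ccccc2)c2ccc(Cl)cc2)cc1` has yet to be measured. It differs from compound 3 by chloro in place of bromo on an aromatic carbon, para to a large group: chloro in place of bromo on an aromatic carbon.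

For the measured compounds named here, one measured step bears directly on this change: a 4.4-fold higher number from compound 2 to compound 3 (0.64 log units; beyond the scatter), a modest move with bromo in place of hydrogen on an aromatic carbon. Compound 1 also carries chloro, but its core differs from that of compound 4, so it offers no single-change comparison. Chloro replaces bromo here, not hydrogen, so a smaller step towards a lower number is expected, perhaps none beyond the scatter. The expected change is a 1.6-fold lower number from compound 3 to compound 4 (0.20 log units; within the scatter). For compound 4 the estimated value is 11000 nM, with an expected range of 5500 nM to 22000 nM.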

Compound 4, half-maximal inhibitory concentration: 8010 nM
For compound 4 the middle estimate is 1.4-fold (0.14 log units) above the measured one, within the range that was stated.
By their numbers in this assay, from the lowest: compounds 2 and 4 (each within the scatter of the next); then compound 3; then compound 1.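

For the compounds shown here, until now only the step from hydrogen to bromo was known at this position; in this assay the direct exchange of the two halogens gives a 2.2-fold lower number from compound 3 to compound 4 (0.33 log units; beyond the scatter) and so separates them, though only modestly. Chloro, read against hydrogen, gives a 2.0-fold higher number from compound 2 to compound 4 (0.30 log units; within the scatter) and does not clearly separate from it, whereas bromo gives a 4.4-fold higher number from compound 2 to compound 3 (0.64 log units; beyond the scatter) and does, so the penalty seen earlier does not carry over in full to every halogen at this position. Nothing measured here accounts for the difference between bromo and chloro.

On these data alone, whether a methoxy group or an amine at this position would stay level with hydrogen or move as bromo does remains open. It is also open whether bromo and chloro would differ in the same way on the core of compound 1, which is shown only with chloro.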